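Sulfonate esters of arabinosylcytosines: methyl versus 4-methylphenyl

This account rests on a few compounds, and the source may have more. Where it says the series, first, only, none or still open, it means among the compounds named here.

Measured so far:
- compound 1, `Cc1ccc(S(=O)(=O)O[C@@H]2[C@@H](O)[C@H](n3ccc(N)nc3=O)O[C@@H]2CO)cc1`: > 100 ug/mL
- compound 2, `CS(=O)(=O)O[C@@H]1[C@@H](O)[C@H](n2cc(F)c(N)nc2=O)O[C@@H]1CO`: 5.3 ug/mL

In a functional assay on L5178Y cells (Mus musculus) for antiproliferative activity (a lower number here means a stronger inhibitor, a higher number a weaker inhibitor), compound 1 reaches only a limit, > 100 ug/mL, and no number. In this assay, going by the values given here, compound 2 gives 5.3 ug/mL, the single number. The other value shown is the limit just named, as the limit of > 100 ug/mL in this assay, at which 1 of the 2 values shown sits, records. Compound 1 and compound 2 differ in two places, so their two values are set side by side here without a step being drawn between them.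

Compound 3, `Cc1ccc(S(=O)(=O)O[C@@H]2[C@@H](O)[C@H](n3cc(F)c(N)nc3=O)O[C@@H]2CO)cc1`, is not yet measured. Relative to compound 2 the change is 4-methylphenyl in place of methyl on a sulfonyl sulfur.

Among the compounds with values here, no measured step covers this change. The series offers one pointer: compound 1, which carries the same 4-methylphenyl sulfonyl group, sits at the limit given as the limit of > 100 ug/mL in this assay, at which 1 of the 2 values shown sits. On that basis the step from compound 2 to compound 3 is expected to run toward weaker inhibition, beyond the scatter, by a 3.8-fold higher number from compound 2 to compound 3 (0.58 log units; beyond the scatter). For compound 3 the estimate in this assay is 20 ug/mL, with a range from 5 ug/mL to 100 ug/mL.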

Compound 3, concentration for 50% inhibition: 8 ug/mL
The estimate for compound 3 lay 2.5-fold (0.40 log units) above the measured number, within the range that was stated.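

In this assay the sulfonyl sulfur accepts 4-methylphenyl in place of methyl with no change that can be read, as the step of a 1.5-fold higher number from compound 2 to compound 3 (0.18 log units; within the scatter) shows. Going by these compounds alone, this is the first measured reading of that swap, and with fluoro on the aromatic carbon the larger aryl group costs nothing beyond the scatter, so the 4-methylphenyl sulfonyl group alone does not account for a weak result. The change that does separate two compounds here is fluoro in place of hydrogen on an aromatic carbon, with an at least 12-fold lower number from compound 1 to compound 3 (1.09 log units; beyond the scatter) as its step, though one end of that step is a limit and not a number: (the limit of > 100 ug/mL in this assay, at which 1 of the 3 values shown sits).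

On these data alone, the fluoro step is read only with 4-methylphenyl on the sulfonyl sulfur, so whether it has the same size with methyl there remains open. Also open, as far as these compounds go, is how far the sulfonyl sulfur's tolerance extends to an ethyl group, a longer alkyl chain or an aryl ring bearing an amine, and whether chloro in place of fluoro on the aromatic carbon would serve as well.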